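This account rests on a few compounds, and the source may have more. Where it says the series, first, only, none or still open, it means among the compounds named here.

The measured compounds and their values:

Compound 1 `CC1=CC[C@H](C(C)(C)NC(=S)N/N=C/c2ccccc2O)CC1` gives 10800 nM in a functional assay on UACC-62 cells (Homo sapiens) for inhibition, read by sulforhodamine B assay, with a stated time of 48 h; on this read-out higher numbers stand for weaker inhibition of growth and lower numbers for stronger inhibition of growth.
Compound 2 `CC1=CC[C@H](C(C)(C)NC(=S)N/N=C/c2cccc(Cl)c2)CC1` gives 39800 nM in this assay.
Compound 3 `CC1=CC[C@H](C(C)(C)NC(=S)N/N=C(\C)c2ccccc2)CC1` reaches only > 100000 nM in this assay, which is a limit of the assay and not a number.

Compound 3 therefore stands at the top end of what the assay reports; (the limit of > 100000 nM in this assay, at which 1 of the 3 values shown sits). The compound not yet measured, compound 4 `COc1ccc(/C(C)=N/NC(=S)NC(C)(C)[C@H]2CC=C(C)CC2)cc1`, differs from compound 3 in one place: methoxy in place of hydrogen on an aromatic carbon.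

Only one measured step exists among these compounds, and it bears on the step to compound 4 only loosely, since it alters the aromatic ring attached to the carbon with the double bond to nitrogen rather than adding a group to it: a 3.7-fold higher number from compound 1 to compound 2 (0.57 log units; beyond the scatter). Within the data shown here, no measured step adds a methoxy to a ring, and the starting point for compound 3 is a limit rather than a number, so the expected size of the step is uncertain and the weight of the evidence is that compound 4 stays near the limit. Compound 4 is thus estimated to give 120000 nM, with a range from 40000 nM to 300000 nM. This estimate amounts to an expected step that the limit leaves unreadable from compound 3 to compound 4 in this assay.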

Compound 4, concentration for total growth inhibition: > 100000 nM
Compound 4: only a limit was reported; the forecaster's own chance of this, stated with the estimate: 60%; the middle value lies beyond the limit too.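

In this assay compound 4 gives > 100000 nM, a limit of the assay and not a number. Among these compounds, compound 3 also sits at a limit, so no step from compound 3 to compound 4 can be read: the limit of > 100000 nM in this assay, at which 2 of the 4 values shown sit. The compounds shown leave open whether going from phenyl to 4-methoxyphenyl changes growth inhibition at all.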